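One Chlorine Added to the Phenyl Ring of Compound 2

The source may hold more compounds than are shown below. What is called first, only, known or untested is meant among the compounds shown, and "the series" means these compounds.

Measured so far:
compound 1 `CCCCCN(CCCCC)C(=O)N1CCN(C(=O)N(c2ccccc2)c2cccc(Cl)c2)[C@H](C(=O)NCCCN(CC)CC)C1` — 8 nM
compound 2 `CCCCCN(CCCCC)C(=O)[C@H]1CCN(C(=O)N(c2ccccc2)c2ccccc2)[C@H](C(=O)O)C1` — 33 nM

Of the compounds shown here, two have been tested in an assay on CHO cells for binding affinity to Substance-P receptor (Homo sapiens); on this read-out higher numbers stand for weaker inhibition and lower numbers for stronger inhibition. Compound 1 gives 8 nM. Going by the values given here, compound 2 gives 33 nM, which is the highest of the two numbers; its only neighbour, compound 1, sits well lower, and the gap between the two lies beyond the usual scatter. Among the compounds with values here, compound 1 and compound 2 differ at several places at once, so their two values show only that compound 1 gives the lower number, not which part of the structure is responsible.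

Compound 3 `CCCCCN(CCCCC)C(=O)[C@H]1CCN(C(=O)N(c2ccccc2)c2cccc(Cl)c2)[C@H](C(=O)O)C1` is the next step and has not yet been measured. It differs from compound 2 in one place only: chloro in place of hydrogen on an aromatic carbon. Compound 1 also carries this chlorine, but its other differences from compound 2 leave the contribution of the chlorine alone unknown. The step from compound 2 to compound 3 in this assay is therefore expected to be small, toward a lower number, and could stay within the scatter. On that basis compound 3 is estimated at 20 nM, with a range from 8 nM to 50 nM, which amounts to an expected change of a 1.7-fold lower number from compound 2 to compound 3 (0.22 log units; within the scatter).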

Compound 3, half-maximal inhibitory concentration: 20 nM
Compound 3: the middle estimate sits on the measured number at the digits printed, and the stated range covers the measured number.
By their numbers in this assay, from the lowest: compound 1; then compounds 3 and 2 (each within the scatter of the next).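

Going by these compounds alone, replacing phenyl with 3-chlorophenyl, with the rest of the structure unchanged, gives in this assay a 1.7-fold lower number from compound 2 to compound 3 (0.22 log units; within the scatter) as the first reading of this change on its own. Within the data shown here, the earlier pair differed at several places at once, whereas here only one aromatic carbon differs, and this single chloro group, meta to a large group, produces no step that can be told apart from the scatter. No independent measurement bears on this result or accounts for the size of the step.

On these data alone, it remains open whether another group on the same aromatic carbon, such as fluoro, methoxy or trifluoromethyl, would give a step beyond the scatter, and whether chloro on a different carbon of this ring would read the same. Compound 1 still differs from compound 3 at more than one place, so the effect of replacing the carboxylic acid alone with an amide bearing a diethylaminopropyl chain, and that of the other differences in the core, cannot be separated.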